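Moving the Carboxylic Acid Around the Aryl Ring

A few compounds are considered here, and "the series" means these few. Any claim that something is new, unique, unknown or untested is made for them only; others in the source may bear on it.

Compound 1, `CCCCC/C=C\C/C=C\C=C\C=C\[C@@H](SCC(=O)O)[C@@H](O)CCCC(=O)O`: 2 nM
Compound 2, `CCCCC/C=C\C/C=C\C=C\C=C\[C@@H](Sc1ccccc1C(=O)O)[C@@H](O)CCCC(=O)O`: 25.1 nM

In an assay on ileum for binding affinity to cysteinyl leukotriene receptor 1 (Cavia porcellus) (a lower number here means a stronger inhibitor, a higher number a weaker inhibitor), compound 1 gives 2 nM, while compound 2 gives 25.1 nM. Within the data shown here, compound 2 thus stands with the higher of the two numbers, the weaker binder; its only neighbour is compound 1, separated by the step of a 13-fold higher number from compound 1 to compound 2 (1.10 log units; beyond the scatter). Compound 3, `CCCCC/C=C\C/C=C\C=C\C=C\[C@@H](Sc1cccc(C(=O)O)c1)[C@@H](O)CCCC(=O)O`, holds the same atoms as compound 2 joined differently: 3-carboxyphenyl in place of 2-carboxyphenyl on a sulfur. Among the measured compounds shown here, the single measured step, a 13-fold higher number from compound 1 to compound 2 (1.10 log units; beyond the scatter), concerns a different exchange, carboxymethyl for 2-carboxyphenyl, so it shows that this end of the molecule matters for binding but gives no guide to where on the ring the carboxylic acid sits. For the measured compounds named here, with no direct precedent, the expected step of a 1.8-fold higher number from compound 2 to compound 3 (0.25 log units; within the scatter) carries wide uncertainty, a mild weakening being the central guess. Compound 3 is therefore estimated at 45 nM in this assay, within 10 nM to 200 nM.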

Compound 3, inhibition constant: 2 nM
The estimate for compound 3 lay 23-fold (1.35 log units) above the measured number; measured number outside the range, below it.
By their numbers in this assay, from the lowest: compounds 1 and 3 (each within the scatter of the next); then compound 2.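

Where the carboxylic acid sits on the ring matters greatly: in this assay, placing it as 3-carboxyphenyl rather than 2-carboxyphenyl on the sulfur gives a 13-fold lower number from compound 2 to compound 3 (1.10 log units; beyond the scatter) at an otherwise unchanged molecule. The loss seen earlier therefore does not follow from having an aryl ring on the sulfur, since the comparison with the carboxymethyl group shows no change at the digits printed from compound 1 to compound 3 (within the scatter) in this same assay. No supporting measurement is available to explain why this shift in the acid's place has so large an effect.

Still open, as far as these compounds go, is whether the ring needs a carboxylic acid at all, or whether a tetrazole or a primary amide in its place would keep binding this strong. Also open, from the compounds shown here alone, is how a longer chain between the sulfur and the acid would compare with carboxymethyl.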